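The source may hold more compounds than are shown below. What is called first, only, known or untested is meant among the compounds shown, and "the series" means these compounds.

Measured in a functional assay on A549 cells (Homo sapiens) for antiproliferative activity, read by spectrophotometry, with a stated time of 2 days; a higher number here means a weaker inhibitor of growth, a lower number a stronger inhibitor of growth:
- compound 1 `CC(=O)N1CCN(c2ccc(Nc3ncc(C(F)(F)F)c(N4Cc5cccc(N(C)S(C)(=O)=O)c5C4)n3)cc2)CC1`: 1300 nM
- compound 2 `COc1cc(N2CCN(C(C)=O)CC2)ccc1Nc1ncc(C(F)(F)F)c(N2Cc3cccc(N(C)S(C)(=O)=O)c3C2)n1`: 3300 nM
- compound 3 `CN(c1cccc2c1CN(c1nc(Nc3cc(C(F)(F)F)cc(C(F)(F)F)c3)ncc1C(F)(F)F)C2)S(C)(=O)=O`: > 30000 nM, a limit and not a number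

Compound 3 has only a limit, with no number: the limit of > 30000 nM in this assay, at which 1 of the 3 values shown sits. Compound 4 `CN(c1cccc2c1CN(c1nc(Nc3cccc(C(F)(F)F)c3)ncc1C(F)(F)F)C2)S(C)(=O)=O` differs from it in one place: hydrogen in place of trifluoromethyl on an aromatic carbon. For the measured compounds named here, one measured step bears on this, and only loosely: a 2.5-fold higher number from compound 1 to compound 2 (0.40 log units; beyond the scatter), with methoxy in place of hydrogen, a modest step. The present change runs the other way, with a group leaving for hydrogen, so a modest move to a lower number is expected in this assay. The expected step is an at least 2.5-fold lower number from compound 3 to compound 4 (0.39 log units; beyond the scatter), and another result at the limit remains possible. The estimate for compound 4 is 12000 nM, with an expected range of 3500 nM to 30000 nM.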

Compound 4, concentration for 50% growth inhibition: > 30000 nM
Compound 4: a limit, no number; the forecaster's own chance of this, stated with the estimate: 35%; middle value at least 2.5-fold (0.39 log units) away from the limit.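

In this assay compound 3 and compound 4 both stand as limits, not numbers, so no step between them can be read: the limit of > 30000 nM in this assay, at which 2 of the 4 values shown sit.

The compounds shown leave open what hydrogen in place of trifluoromethyl does to growth inhibition.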